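The compounds below may be only part of what the source reports. "The series", "measured", "known", "first", "only" and "open" are said of these compounds alone.

Values in a functional assay on HeLa cells (Homo sapiens) for cytotoxicity, read by MTT assay, with a stated time of 72 h; a higher number here means a weaker inhibitor, a lower number a stronger inhibitor:
- compound 1 `O=C(/C=C/c1ccc([N+](=O)[O-])cc1)Nc1cc2c(Nc3ccc(F)c(Cl)c3)ncnc2cc1O[C@H]1CCOC1`: 27400 nM
- compound 2 `N#Cc1ccc(/C=C/C(=O)Nc2cc3c(Nc4ccc(F)c(Cl)c4)ncnc3cc2O[C@H]2CCOC2)cc1`: "not determined" (no result reported)
- compound 3 `COc1ccc(OC)c(/C=C/C(=O)Nc2cc3c(Nc4ccc(F)c(Cl)c4)ncnc3cc2O[C@H]2CCOC2)c1`: 26800 nM

Going by the values given here, only two numbers are available in this assay, and compound 3 sits level with compound 1 within the scatter. Compound 2 adds nothing to the comparison.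

The next compound is compound 4 `O=C(/C=C/c1ccccc1[N+](=O)[O-])Nc1cc2c(Nc3ccc(F)c(Cl)c3)ncnc2cc1O[C@H]1CCOC1`, which keeps the shared core and the chain of compound 3. It has 2-nitrophenyl in place of 2,5-dimethoxyphenyl on a double-bonded chain carbon bound to a double-bonded chain carbon.

Among the compounds with values here, one measured step bears on this change: a 1.0-fold lower number from compound 1 to compound 3 (0.01 log units; within the scatter). It exchanges 4-nitrophenyl for 2,5-dimethoxyphenyl at the same place and stays within the scatter. Within the data shown here, a nitrophenyl and the 2,5-dimethoxyphenyl have therefore given matching numbers once, but no measured compound yet carries 2-nitrophenyl, so this single step is thin support.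

No shift in either direction beyond the scatter is expected in this assay. The expected step is a 1.0-fold higher number from compound 3 to compound 4 (0.00 log units; within the scatter). For compound 4 the estimated value is 27000 nM, with an expected range from 13000 nM to 50000 nM.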

Compound 4, half-maximal inhibitory concentration: 29600 nM
Compound 4: the middle estimate sits 1.1-fold (0.04 log units) below what was measured; the measured number falls inside the stated range.
By their numbers in this assay, from the lowest: compounds 3, 1 and 4 (each within the scatter of the next).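

In this assay, putting 2-nitrophenyl in place of 2,5-dimethoxyphenyl on a double-bonded chain carbon bound to a double-bonded chain carbon gives a 1.1-fold higher number from compound 3 to compound 4 (0.04 log units; within the scatter), and putting it in place of 4-nitrophenyl at the same place gives a 1.1-fold higher number from compound 1 to compound 4 (0.03 log units; within the scatter). Going by these compounds alone, the single earlier step compared only two groups at this place, whereas compounds 1, 3 and 4 now give three groups whose numbers all lie level within the scatter, and the pair of compound 1 and compound 4 adds a direct reading: 4-nitrophenyl and 2-nitrophenyl cannot be told apart here. Nothing measured in this set offers an explanation for why these numbers coincide.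

Going by these compounds, all three groups with numbers are substituted phenyls, so it remains open whether a group of another kind at this place, such as a carboxylic acid or a chain ending in an amine, would move the number beyond the scatter. Whether the shared core rather than this group sets the common level also stays open, since the core is the same in every compound shown.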